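The source may hold more compounds than are shown below. What is called first, only, known or untested is meant among the compounds shown, and "the series" means these compounds.

In a functional assay on HEK293 cells for agonist activity at D(4) dopamine receptor (Homo sapiens), read by FLIPR (on this read-out lower numbers stand for an effect already at smaller amounts and higher numbers for an effect only at larger amounts of compound), compound 1 `Cc1cccc(C(=O)NCN2CCC(c3cccc[n+]3[O-])CC2)c1` gives 89 nM, while compound 2 `N#Cc1cccc(C(=O)NCN2CCC(c3cccc[n+]3[O-])CC2)c1` gives 840 nM. For the measured compounds named here, the single change between them, (cyano in place of methyl on an aromatic carbon), produced a 9.4-fold higher number from compound 1 to compound 2 (0.97 log units; beyond the scatter). Compound 3 `Cc1cccc(NC(=O)CN2CCC(c3ccccc3C)CC2)c1` gives 340 nM. The difference between the core of compound 1 and the core of compound 3 is not broken down here. Compound 4 `Cc1cccc(NC(=O)CN2CCC(c3ccccc3C#N)CC2)c1` has not yet been measured. It carries the same kind of change, (cyano in place of methyl on an aromatic carbon), but at a place described as ortho to a large group rather than meta to a large group, and on a different core. Because the same kind of change gave a 9.4-fold higher number from compound 1 to compound 2 (0.97 log units; beyond the scatter), a weakening step is expected, though the different core and place leave its size uncertain. The step expected from this change is a 4.4-fold higher number from compound 3 to compound 4 (0.64 log units; beyond the scatter). Compound 4 is therefore estimated at 1500 nM, with a likely range from 400 nM to 5000 nM.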

Compound 4, half-maximal effective concentration: 8 nM
Compound 4: middle estimate off by 190-fold (2.27 log units), on the high side; the whole stated range lies above it.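

In this assay the change from methyl to cyano gave a 43-fold lower number from compound 3 to compound 4 (1.63 log units; beyond the scatter) on the core of compound 3, the opposite direction to the earlier step. The change therefore does not carry over between these two cores with the same direction or size: the same change on two cores in this assay, a 9.4-fold higher number (0.97 log units; beyond the scatter) from compound 1 to compound 2 and a 43-fold lower number (1.63 log units; beyond the scatter) from compound 3 to compound 4, 400-fold (2.60 log units) apart, beyond the scatter of two such steps. This does not show what causes the reversal, since the two pairs differ in their core and also in the place of the change, and two pairs alone cannot separate these.

Still open, from the compounds shown here alone, is how another group at the same place on the core of compound 3, such as an amine or a carboxylic acid, would compare with cyano. Also open, going by these compounds, is whether cyano at the place it holds in compound 2 would lower the number on the core of compound 3.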